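Mirror-Image Twin of a Cytotoxic Triazole Compound

A few compounds are considered here, and "the series" means these few. Any claim that something is new, unique, unknown or untested is made for them only; others in the source may bear on it.

Compound 1, `CC[C@H](CCn1cncn1)c1ccccc1`: 97.7 ug/mL
Compound 2, `c1ccc([C@H](CCn2cncn2)C2CCCCC2)cc1`: 24.8 ug/mL

Of the compounds shown here, two have been tested in an ADME assay on HEp-2 cells (Homo sapiens) for cytotoxicity, read by MTT assay, with a stated time of 3 days; on this read-out lower numbers stand for higher toxicity in this test and higher numbers for lower toxicity in this test. Compound 1 gives 97.7 ug/mL, while compound 2 gives 24.8 ug/mL. Of these two numbers, compound 2 has the lower one, so it is the more toxic of the pair, and the gap to compound 1 lies beyond the usual scatter.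

Compound 3, `c1ccc([C@@H](CCn2cncn2)C2CCCCC2)cc1`, is the mirror image of compound 2: the two compounds have the same atoms and bonds and differ only in configuration as drawn: 1 of 1 stereo elements differ; a stereocentre at a saturated chain carbon is drawn R in compound 2 and S in compound 3. Among the measured compounds shown here, nothing measured here says how the two mirror images behave in this assay, since no pair of compounds differing only in configuration has been measured. In a cell-killing readout of this kind, a change of handedness alone is expected to give no step beyond the scatter, so the estimated step of a 1.0-fold higher number from compound 2 to compound 3 (0.00 log units; within the scatter) is small. Compound 3 is therefore expected to give about 25 ug/mL, within a range of 10 ug/mL to 65 ug/mL.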

Compound 3, half-maximal cytotoxic concentration: 21.8 ug/mL
Beside the measured number, compound 3's estimate is 1.1-fold (0.06 log units) above it; the range from low to high includes it.
By their numbers in this assay, from the lowest: compounds 3 and 2 (each within the scatter of the next); then compound 1.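

In this assay, turning the stereocentre at this saturated chain carbon from R to S gives a 1.1-fold lower number from compound 2 to compound 3 (0.06 log units; within the scatter) and so no readable change in toxicity for this pair of cyclohexyl compounds. Among the compounds shown here, compound 1 and compound 3 form the first pair that differs in one place, and cyclohexyl in place of ethyl on that carbon gives a 4.5-fold lower number from compound 1 to compound 3 (0.65 log units; beyond the scatter) and so a real move towards higher toxicity in this test. The handedness comparison is a clean one, since only one thing separates the two mirror images: the fact that compounds 2 and 3 differ only in the configuration as drawn.

The compounds shown leave open how an isopropyl group or a longer chain would behave at this carbon, and so whether the number moves gradually from ethyl to cyclohexyl. They also leave open whether handedness would stay just as silent with ethyl in place of cyclohexyl.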